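Swapping a furan for a thiophene on a shared core

This account rests on a few compounds, and the source may have more. Where it says the series, first, only, none or still open, it means among the compounds named here.

Compound 1 `COc1ccc(OC)c(C(=O)/C=C/c2ccco2)c1` gives 19000 nM
Compound 2 `COc1ccc(OC)c(C(=O)/C=C/c2ccoc2)c1` gives 12000 nM
Compound 3 `COc1ccc(OC)c(C(=O)/C=C/c2cccs2)c1` has not yet been measured

In a functional assay on Hep 3B2 cells (Homo sapiens) for cytotoxicity, read by MTT assay (on this read-out higher numbers stand for weaker inhibition and lower numbers for stronger inhibition), compound 2 gives 12000 nM and so cannot be told apart from compound 1. The change to compound 3 is thiophen-2-yl in place of furan-3-yl on a double-bonded chain carbon bound to a double-bonded chain carbon and puts thiophen-2-yl in place of furan-3-yl on a double-bonded chain carbon bound to a double-bonded chain carbon. Within the data shown here, only one measured step bears on this, and it is indirect. That step is a 1.6-fold lower number from compound 1 to compound 2 (0.20 log units; within the scatter) and it exchanges furan-2-yl for furan-3-yl at the same place. Among the measured compounds shown here, no measured compound carries thiophen-2-yl, so the data offer no direct guide. For the measured compounds named here, with only that small step to go on, no change beyond the scatter is expected in this assay for this swap. The expected step is a 1.1-fold higher number from compound 2 to compound 3 (0.03 log units; within the scatter) and stays within the scatter. The estimated value for compound 3 is 13000 nM with an expected range of 6000 nM to 28000 nM around it.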

Compound 3, half-maximal inhibitory concentration: 8400 nM
Estimate against measurement, compound 3: 1.5-fold (0.19 log units) above, and the stated range covers the measured number.
By their numbers in this assay, from the lowest: compounds 3, 2 and 1 (each within the scatter of the next, the first and the last beyond it).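

In this assay, among these compounds, the only step at this place that clears the scatter is a 2.3-fold lower number from compound 1 to compound 3 (0.35 log units; beyond the scatter), a modest change that puts thiophen-2-yl in place of furan-2-yl. Against furan-3-yl, the same group cannot be told apart, at a 1.4-fold lower number from compound 2 to compound 3 (0.15 log units; within the scatter), so the sulfur-bearing ring is separated from only one of the two furans. No measurement available here explains why the rings compare in this way.

The compounds shown leave open whether thiophen-3-yl on a double-bonded chain carbon bound to a double-bonded chain carbon would follow thiophen-2-yl, which would show whether the ring's point of attachment matters with sulfur as it does not measurably with oxygen. They also leave open how a phenyl ring or an amine would fare at this place on the shared core.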